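Swapping chloro for hydroxymethyl on the fused ring of compound 1

The source may report more compounds than this note shows. Statements on the series, on what has been measured and on what is new or still open speak of the compounds shown alone.

Measured compounds:
compound 1, `CC#C[C@@H](CC(=O)O)c1ccc(OC[C@H]2COc3ccc(Cl)cc3O2)cc1`: 50 nM
compound 2, `CC#C[C@H](CC(=O)O)c1ccc(OC[C@@H]2COc3ccc(Cl)cc3O2)cc1`: 5040 nM
compound 3, `CC#C[C@@H](CC(=O)O)c1ccc(OC[C@@H]2COc3ccc(Cl)cc3O2)cc1`: 260 nM

In a functional assay on HEK293 cells for agonist activity at Free fatty acid receptor 1 (Homo sapiens), read by fluorescence and calcium flux, with a stated time of 10 min (on this read-out higher numbers stand for an effect only at larger amounts of compound and lower numbers for an effect already at smaller amounts), compound 1 gives 50 nM and stands with the lowest number of the three. Its nearest neighbour is compound 3, which in this assay gives 260 nM; the step is a 5.2-fold higher number from compound 1 to compound 3 (0.72 log units; beyond the scatter). Compound 2 in this assay gives 5040 nM, a step of a 100-fold higher number from compound 1 to compound 2 (2.00 log units; beyond the scatter) from compound 1, and between the other two the step is a 19-fold lower number from compound 2 to compound 3 (1.29 log units; beyond the scatter). All three measured steps rest on configuration alone, as shown by the fact that compounds 1 and 2 differ only in the configuration as drawn, the fact that compounds 1 and 3 differ only in the configuration as drawn and (the fact that compounds 2 and 3 differ only in the configuration as drawn).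

Compound 4, `CC#C[C@@H](CC(=O)O)c1ccc(OC[C@H]2COc3ccc(CO)cc3O2)cc1`, keeps the configuration of compound 1 and changes a substituent instead: hydroxymethyl in place of chloro on an aromatic carbon. Within the data shown here, none of the measured steps concerns a change of substituent, so they give no direct guide to the size of this step. The core and the configuration that give compound 1 its low number are retained, and the change is small in atom count, so a step of no more than modest size is expected, a 2.4-fold higher number from compound 1 to compound 4 (0.38 log units; beyond the scatter), with the direction uncertain. For compound 4 in this assay the expected value is 120 nM, within a range from 30 nM to 500 nM.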

Compound 4, half-maximal effective concentration: > 30000 nM
Compound 4: only a limit was reported (the forecaster's own chance of this, stated with the estimate: 2%); middle value at least 250-fold (2.39 log units) from the limit.
By their numbers in this assay, from the lowest: compound 1; then compound 3; then compound 2. At a limit, above all of these: compound 4.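

In this assay compound 4 gives > 30000 nM, and this value is a limit of the assay, not a number. With the configuration of compound 1 kept, hydroxymethyl in place of chloro on an aromatic carbon gives an at least 600-fold higher number from compound 1 to compound 4 (2.77 log units; beyond the scatter), so the number depends strongly on which group sits at this place on the six-membered aromatic ring. Among these compounds, until now every measured change was one of configuration, the largest being a 100-fold higher number from compound 1 to compound 2 (2.00 log units; beyond the scatter), and this is the first step to show that a change of substituent alone, with both stereocentres untouched, can also be large, whereas the earlier steps rested on configuration only: the fact that compounds 1 and 2 differ only in the configuration as drawn.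

As far as these compounds go, a single replacement for chloro cannot show which feature of hydroxymethyl goes with this step, so how a methyl, a methoxy, a fluoro or an aminomethyl group would read at this place stays open. Also open, from the compounds shown here alone, is whether hydroxymethyl would give a step of similar size on the configurations of compound 2 and compound 3, or whether the step belongs to the configuration of compound 1.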